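Compound 3 to compound 4: methyl to benzyl

The source may report more compounds than this note shows. Statements on the series, on what has been measured and on what is new or still open speak of the compounds shown alone.

In an ADME assay on L6 cells (Rattus norvegicus) for cytotoxicity (on this read-out lower numbers stand for stronger inhibition and higher numbers for weaker inhibition), compound 1 (`O=C(NN1CCc2ccccc2C1)c1cc([N+](=O)[O-])ccc1F`) gives > 317000 nM as a limit of the assay and not a number. Compound 2 (`O=[N+]([O-])c1ccc2c(c1)C([O-])=N[N+]21CCCCCC1`) gives > 382000 nM in this assay and this too is a limit and not a number. Going by the values given here, compound 3 (`Cn1c(=O)c2cc([N+](=O)[O-])ccc2n1Cc1ccccc1`) gives 166000 nM as the only true number among the three, which makes it the single anchor for what follows.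

The next compound to read is compound 4 (`O=c1c2cc([N+](=O)[O-])ccc2n(Cc2ccccc2)n1Cc1ccccc1`), which has no value yet. Its difference from compound 3 is phenyl in place of hydrogen on a saturated chain carbon bound to an aromatic nitrogen and amounts to phenyl in place of hydrogen on a saturated chain carbon bound to an aromatic nitrogen. Cut one bond further out, this reads methyl to benzyl. Among the compounds with values here, no measured pair in this set differs in one place, so no observed step size can be carried over. The expectation therefore rests on compound 3 at 166000 nM and on the structural change alone, and it stays wide. A moderate move towards stronger inhibition in this assay is expected, somewhat beyond the scatter. The estimated 2.4-fold lower number from compound 3 to compound 4 (0.38 log units; beyond the scatter) carries that direction. For compound 4 the expected value is 70000 nM with an estimated range from 20000 nM to 220000 nM in this read-out.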

Compound 4, half-maximal inhibitory concentration: 37300 nM
The estimate for compound 4 lay 1.9-fold (0.27 log units) above the measured number, within the range that was stated.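

In this assay the series now has its first step read at a single place, a 4.5-fold lower number from compound 3 to compound 4 (0.65 log units; beyond the scatter) on going from methyl to benzyl, and it points towards stronger inhibition. The saturated chain carbon bound to an aromatic nitrogen is therefore a place where a change moves this read-out beyond the scatter, although this rests on one pair, one entering group and one core. No measurement shown bears on why the number moves.

Whether the step depends on the phenyl ring itself stays open, since the compounds shown hold no longer alkyl chain such as propyl, no saturated ring such as cyclohexyl, and no phenyl carrying an amine or a carboxylic acid on this carbon. On these data alone, compound 1 and compound 2 differ from the others in more than one place and are reported only as limits of the assay, so no further steps can be read and the reach of this single change across the series remains unknown.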